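The source may report more compounds than this note shows. Statements on the series, on what has been measured and on what is new or still open speak of the compounds shown alone.

Compound 1 `O=c1nc2oc(CCCCl)cc2cn1Cc1cn(Cc2ccccc2)nn1`: 9580 nM
Compound 2 `O=c1nc2oc(C3CC3)cc2cn1Cc1cn(-c2ccc(Cl)cc2)nn1`: > 100000 nM

In a functional assay on HeLa cells (Homo sapiens) for antiproliferative activity, read by MTT assay, with a stated time of 72 h (on this read-out higher numbers stand for weaker inhibition and lower numbers for stronger inhibition), compound 1 gives 9580 nM. Compound 2 gives only a limit in this assay, > 100000 nM. From the compounds shown here alone, compound 2 thus stands at the limit of > 100000 nM in this assay, at which 1 of the 2 values shown sits, so its true value is unknown. Going by the values given here, no pair of measured compounds differs in one place, so no measured step is available.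

Compound 3 `O=c1nc2oc(C3CC3)cc2cn1Cc1cn(Cc2ccccc2)nn1` differs from compound 2 by benzyl in place of 4-chlorophenyl on an aromatic nitrogen. The rest of compound 3 is the same as compound 2, while the benzyl is shared with compound 1, which gives a number in this assay at 9580 nM. On that basis the step from compound 2 to compound 3 is expected to be an at least 3.3-fold lower number from compound 2 to compound 3 (0.52 log units; beyond the scatter), toward stronger inhibition, though with wide uncertainty. Compound 3 is therefore estimated at 30000 nM, with a likely range from 8000 nM to 100000 nM.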

Compound 3, half-maximal inhibitory concentration: 50000 nM
Compound 3: middle estimate off by 1.7-fold (0.22 log units), on the low side; measured number inside the range.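

In this assay, benzyl in place of 4-chlorophenyl on the aromatic nitrogen gives an at least 2.0-fold lower number from compound 2 to compound 3 (0.30 log units; that floor lies within the scatter), so this change has no firm size yet. Compound 2 has only a limit, which leaves the true size of that step unknown: the limit of > 100000 nM in this assay, at which 1 of the 3 values shown sits.

With benzyl kept on that nitrogen, the group on the aromatic carbon also matters: cyclopropyl in place of 3-chloropropyl gives a 5.2-fold higher number from compound 1 to compound 3 (0.72 log units; beyond the scatter), which makes compound 1 the stronger of this pair.

Still open, from the compounds shown here alone, is whether the chlorine or the link to the ring accounts for the difference on the nitrogen, and a plain phenyl there would help separate the two. Also open, going by these compounds, is how an amine or a carboxylic acid at the end of the propyl chain, in place of the chlorine, would read in this assay.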